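A few compounds are considered here, and "the series" means these few. Any claim that something is new, unique, unknown or untested is made for them only; others in the source may bear on it.

Compound 3 `Cc1nc(-c2ccccc2)c(C(=O)N2CCN(c3ccc(Cl)c(Cl)c3)CC2)o1` is one of three compounds examined in a functional assay on HL-60 cells (Homo sapiens) for inhibition, read by MTT assay, with a stated time of 72 h; on this read-out lower numbers stand for stronger inhibition and higher numbers for weaker inhibition. In this assay compound 3 gives 124 nM, the lowest of the two numbers reported. Compound 2 `COc1cc(OC)cc(N2CCN(C(=O)c3onc(C)c3-c3ccccc3)CC2)c1`, which carries a different core and a 3,5-dimethoxyphenyl group on the ring nitrogen, gives 152 nM in this assay; the gap between compound 2 and compound 3 is well within the scatter, so neither can be called the more potent. Compound 1 `COc1ccc(-c2nc(C)oc2C(=O)N2CCN(c3cccc(Cl)c3)CC2)cc1`, with a 3-chlorophenyl group on the ring nitrogen and a methoxyphenyl group on its core, is recorded in this assay as "not active" (no number reported), with no number given.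

Compound 4 `CC(=O)c1ccc(N2CCN(C(=O)c3oc(C)nc3-c3ccccc3)CC2)cc1` is the next compound to be tested and is not yet measured. It differs from compound 3 in one place: 4-acetylphenyl in place of 3,4-dichlorophenyl on an amine nitrogen in a ring. Among the compounds with values here, no pair of measured compounds differing only in this group is available, so the effect of exchanging the dichlorophenyl for the acetylphenyl can only be guessed. Both measured numbers sit close together despite quite different groups on that nitrogen, and compound 1 shows that a change there can abolish activity. Compound 4 is therefore expected to lose some potency, with an estimated step of a 2.8-fold higher number from compound 3 to compound 4 (0.45 log units; beyond the scatter) in this assay. The estimate for compound 4 is 350 nM, within a range of 90 nM to 1500 nM.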

Compound 4, half-maximal inhibitory concentration: "not active" (no number reported)
The entry for compound 4 holds no number; there is nothing to compare the estimate with.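

Within the data shown here, compound 4 is recorded without a number in this assay, so no step from compound 3 to compound 4 can be read. The compounds shown leave open how the group on the ring nitrogen governs activity, as only compound 2 and compound 3 carry numbers. Nothing shown offers an explanation for the result for compound 4.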